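A few compounds are considered here, and "the series" means these few. Any claim that something is new, unique, unknown or untested is made for them only; others in the source may bear on it.

Three compounds share one core and differ only in the aryl group at the far end of the chain. Compound 1 `COc1ccc(/C=C/C(=O)NCCCCNc2ccnc3cc(Cl)ccc23)cc1` carries a 4-methoxyphenyl there and in a functional assay on Caco-2 cells (Homo sapiens) for antiproliferative activity, read by sulforhodamine B assay, with a stated time of 2 days (on this read-out higher numbers stand for weaker inhibition of growth and lower numbers for stronger inhibition of growth), compound 1 gives 30700 nM. Compound 2 `O=C(/C=C/c1cccc(F)c1)NCCCCNc1ccnc2cc(Cl)ccc12` carries a 3-fluorophenyl, and in this assay compound 2 gives 25400 nM. Compound 3 `O=C(/C=C/c1ccc(F)cc1)NCCCCNc1ccnc2cc(Cl)ccc12` carries a 4-fluorophenyl, and in this assay compound 3 gives 15000 nM, the lowest of the three numbers. The step of a 2.0-fold lower number from compound 1 to compound 3 (0.31 log units; beyond the scatter) is the only one beyond the scatter; the steps of a 1.2-fold lower number from compound 1 to compound 2 (0.08 log units; within the scatter) and a 1.7-fold lower number from compound 2 to compound 3 (0.23 log units; within the scatter) both fall within it.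

Compound 4 `O=C(/C=C/c1ccccc1[N+](=O)[O-])NCCCCNc1ccnc2cc(Cl)ccc12` changes the aryl group again: 2-nitrophenyl in place of 4-fluorophenyl on a double-bonded chain carbon bound to a double-bonded chain carbon. Among the compounds with values here, no measured step introduces a nitro group, so the two fluorophenyl steps are the only guide, and those suggest that swapping one small aryl substituent for another moves the number little. The expected step of a 1.3-fold higher number from compound 3 to compound 4 (0.12 log units; within the scatter) is therefore small, with no clear direction beyond the scatter. For compound 4 the estimated value in this assay is 20000 nM, between 8000 nM and 50000 nM.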

Compound 4, concentration for 50% growth inhibition: 11900 nM
Compound 4: the middle estimate sits 1.7-fold (0.23 log units) above what was measured, and the stated range covers the measured number.
By their numbers in this assay, from the lowest: compounds 4, 3, 2 and 1 (each within the scatter of the next, the first and the last beyond it).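

Replacing 4-fluorophenyl with 2-nitrophenyl gives a 1.3-fold lower number from compound 3 to compound 4 (0.10 log units; within the scatter) in this assay, so a nitro group, new to this series, leaves the number within the scatter of the fluoro compound. The same aryl group does stand apart from the other two, with a 2.1-fold lower number from compound 2 to compound 4 (0.33 log units; beyond the scatter) and a 2.6-fold lower number from compound 1 to compound 4 (0.41 log units; beyond the scatter), which gives compound 2 its first step beyond the scatter and widens the overall spread of the series slightly. Nothing measured here explains these differences.

The aryl groups shown carry only fluoro, methoxy or nitro substituents, so it remains open how an amine or a carboxylic acid on the ring would behave, and whether 3-nitrophenyl or 4-nitrophenyl would match 2-nitrophenyl. From the compounds shown here alone, the effect of a longer chain also remains open.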